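This account rests on a few compounds, and the source may have more. Where it says the series, first, only, none or still open, it means among the compounds named here.

Measured so far, in an assay on membranes from CHO cells for displacement of a labelled ligand from adenosine receptor A1 (Homo sapiens), read by scintillation counting, with a stated time of 60 min, tested at 1 uM; on this read-out higher numbers stand for more inhibition at the one concentration tested (going by the name of the read-out) and lower numbers for less inhibition:

Compound 1 `CC1=C(C(=O)OCC(C)C)C(c2ccoc2)NC(=S)N1` gives 12%.
Compound 2 `CC1=C(C(=O)OC(C)(C)C)C(c2ccoc2)NC(=S)N1` gives 18%.
Compound 3 `CC1=C(C(=O)OCc2ccccc2)C(c2ccoc2)NC(=S)N1` gives 25%.

Compound 2 stands second highest of these three numbers. Its two neighbours lie close on either side: a number 6 percentage points higher from compound 1 to compound 2 (within the scatter), and a number 7 percentage points higher from compound 2 to compound 3 (within the scatter), both within the usual scatter. Only the outer pair shows a step that counts, a number 13 percentage points higher from compound 1 to compound 3 (beyond the scatter), and even that one is modest. All three measured compounds share the same core and differ from one another only in the group on the oxygen next to the carbonyl group.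

Compound 4 `CC1=C(C(=O)OC(C)(C)C)C(c2cccs2)NC(=S)N1` is the compound not yet measured. It keeps the tert-butyl ester of compound 2 and changes the ring held by the saturated ring carbon instead: thiophen-2-yl in place of furan-3-yl on a saturated ring carbon. For the measured compounds named here, no measured step touches that ring, so none of the three steps bears directly on this change; what they do show is that the whole series so far sits in a narrow band of weak displacement. With nothing pointing in either direction, the expected step from compound 2 to compound 4 is none beyond the scatter: no change at the digits printed from compound 2 to compound 4 (within the scatter). Compound 4 is therefore estimated at 18%, with a range from 4% to 36%.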

Compound 4, a percentage reported as inhibition, at one concentration (the size of the read-out at that concentration, not a potency): 22%
Estimate against measurement, compound 4: 4 percentage points below; measured number inside the range.
By their numbers in this assay, from the lowest: compounds 1, 2, 4 and 3 (each within the scatter of the next, the first and the last beyond it).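

In this assay, for the compounds shown here, the ring on the saturated ring carbon is the only thing that changes, and the step is a number 4 percentage points higher from compound 2 to compound 4 (within the scatter), so this first look at the position shows no readable difference on exchanging furan-3-yl for thiophen-2-yl. The two groups match in what can be counted, with the same number of heavy atoms, hydrogen-bond donors and acceptors and no net charge, but sulfur replaces oxygen and the ring is attached through a different ring atom, so this one pair cannot separate those two differences. Nothing available explains why the reading stays within the scatter.

The compounds shown leave open whether thiophen-2-yl would behave the same way alongside the benzyl ester of compound 3, since it appears here only with the tert-butyl ester. They also leave open whether a quite different group on this saturated ring carbon, such as a pyridine ring, a cyclohexyl ring, or a phenyl ring carrying an amine or a carboxylic acid, would move the number beyond the scatter.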